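Extending the amide substituent: compound 3 to compound 4

The source may hold more compounds than are shown below. What is called first, only, known or untested is meant among the compounds shown, and "the series" means these compounds.

Measured compounds:
compound 1, `NCC(N)CCc1c[nH]c2ccc(F)cc12`, gives 26 nM in an assay on isolated protein for inhibition of Myeloperoxidase (Homo sapiens), read by ELISA, with a stated time of 5 min; a higher number here means a weaker inhibitor, a lower number a stronger inhibitor
compound 2, `N#CCCCc1c[nH]c2ccc(F)cc12`, gives 72 nM in this assay
compound 3, `CNC(=O)CCCc1c[nH]c2ccc(F)cc12`, gives 95 nM in this assay

Compound 3 holds the highest of the three numbers. Its nearest neighbour is compound 2, and a 1.3-fold higher number from compound 2 to compound 3 (0.12 log units; within the scatter) lies within the scatter. Compound 1 stands furthest away, as a 3.7-fold higher number from compound 1 to compound 3 (0.56 log units; beyond the scatter) shows; likewise a 2.8-fold higher number from compound 1 to compound 2 (0.44 log units; beyond the scatter) passes beyond the scatter.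

Compound 4, `CCNC(=O)CCCc1c[nH]c2ccc(F)cc12`, differs from compound 3 in one place: methyl in place of hydrogen on a saturated chain carbon bound to an amide-type nitrogen. Among the measured compounds shown here, none of the measured steps alters the substituent on the amide-type nitrogen. For the measured compounds named here, the one step that touches the chain end, a 1.3-fold higher number from compound 2 to compound 3 (0.12 log units; within the scatter), exchanged cyano for methylcarbamoyl and stayed within the scatter, while the two larger steps, a 2.8-fold higher number from compound 1 to compound 2 (0.44 log units; beyond the scatter) and a 3.7-fold higher number from compound 1 to compound 3 (0.56 log units; beyond the scatter), both concern the loss of 1,2-diaminoethyl and do not bear on a change at the amide. Adding one carbon to the amide substituent is therefore expected to move this assay by no more than the scatter, in either direction. For compound 4 the expected value in this assay is 110 nM, with a range from 50 nM to 250 nM. This estimate means a step of a 1.2-fold higher number from compound 3 to compound 4 (0.06 log units; within the scatter), which is expected to remain within the scatter.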

Compound 4, half-maximal inhibitory concentration: 243 nM
The estimate for compound 4 lay 2.2-fold (0.34 log units) below the measured number, within the range that was stated.
By their numbers in this assay, from the lowest: compound 1; then compounds 2 and 3 (each within the scatter of the next); then compound 4.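

In this assay the substituent on the amide-type nitrogen proves not to be neutral, since methyl in place of hydrogen on the saturated chain carbon bound to that nitrogen gives a 2.6-fold higher number from compound 3 to compound 4 (0.41 log units; beyond the scatter) and passes beyond the scatter. Cyano and methylcarbamoyl had stayed within the scatter of each other, but ethylcarbamoyl stands clear of the nitrile, with a 3.4-fold higher number from compound 2 to compound 4 (0.53 log units; beyond the scatter) as the step. Losing 1,2-diaminoethyl now costs more when ethylcarbamoyl replaces it, as a 9.3-fold higher number from compound 1 to compound 4 (0.97 log units; beyond the scatter) is the largest step in the set.

On these data alone, whether a propyl group or a longer chain on the amide nitrogen would raise the number further, or an unsubstituted amide would lower it, remains open. The data offer no evidence on why this one added carbon moves the number.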